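Replacing Dimethylamino with Hydroxy on Compound 3

A few compounds are considered here, and "the series" means these few. Any claim that something is new, unique, unknown or untested is made for them only; others in the source may bear on it.

In a functional assay on DU-145 cells (Homo sapiens) for cytotoxicity, read by sulforhodamine B assay, with a stated time of 48 h (on this read-out higher numbers stand for weaker inhibition and lower numbers for stronger inhibition), compound 1 `C[C@H]1CC[C@@H]2[C@@H](OC(=O)[C@]23CC(c2c(Cl)cccc2Cl)=NO3)[C@]2(C)C(=O)C=C[C@@]12O` gives 38000 nM, compound 2 `C[C@H]1CC[C@@H]2[C@@H](OC(=O)[C@]23CC(c2ccccc2)=NO3)[C@]2(C)C(=O)C=C[C@@]12O` gives 39800 nM, and compound 3 `C[C@H]1CC[C@@H]2[C@@H](OC(=O)[C@]23CC(c2ccc(N(C)C)cc2)=NO3)[C@]2(C)C(=O)C=C[C@@]12O` gives 4500 nM, the lowest of the three numbers. The aryl change in a 1.0-fold higher number from compound 1 to compound 2 (0.02 log units; within the scatter) made no difference beyond the scatter, whereas compound 3 stands clear of both others, with an 8.4-fold lower number from compound 1 to compound 3 (0.93 log units; beyond the scatter). Compound 4 `C[C@H]1CC[C@@H]2[C@@H](OC(=O)[C@]23CC(c2ccc(O)cc2)=NO3)[C@]2(C)C(=O)C=C[C@@]12O` has hydroxy in place of dimethylamino on an aromatic carbon. Among the compounds with values here, the nearest guide is an 8.8-fold lower number from compound 2 to compound 3 (0.95 log units; beyond the scatter), and no measured compound carries hydroxy. Losing dimethylamino is therefore expected to give back much of that modest step, raising the number in this assay. The expected change is a 4.0-fold higher number from compound 3 to compound 4 (0.60 log units; beyond the scatter). For compound 4 the estimate is 18000 nM, with an expected range of 6000 nM to 50000 nM.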

Compound 4, half-maximal inhibitory concentration: 93000 nM
Compound 4: the middle estimate sits 5.2-fold (0.71 log units) below what was measured; measured number above the stated range.
By their numbers in this assay, from the lowest: compound 3; then compounds 1 and 2 (each within the scatter of the next); then compound 4.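

In this assay, hydroxy does more than give back the gain from dimethylamino, with a 21-fold higher number from compound 3 to compound 4 (1.32 log units; beyond the scatter). Compared with hydrogen on this aromatic carbon, it moves the number the opposite way from dimethylamino, with a 2.3-fold higher number from compound 2 to compound 4 (0.37 log units; beyond the scatter), so the substituent here can shift the number in either direction; compound 4 also sits apart from the 2,6-dichlorophenyl compound, with a 2.4-fold higher number from compound 1 to compound 4 (0.39 log units; beyond the scatter). No available evidence accounts for these steps. On these data alone, whether the lower number is particular to dimethylamino remains open, as does what an amino, diethylamino or methoxy group on this carbon would give.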